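A few compounds are considered here, and "the series" means these few. Any claim that something is new, unique, unknown or untested is made for them only; others in the source may bear on it.

Measured in a functional assay on MCF7 cells (Homo sapiens) for cytotoxicity, read by MTT assay, with a stated time of 72 h (on this read-out lower numbers stand for stronger inhibition and higher numbers for weaker inhibition), so far:
- compound 1, `O=C(CSC(=S)N[C@H]1CCOC1=O)Nc1ccccc1F`: 28600 nM
- compound 2, `O=C(CSC(=S)N[C@H]1CCOC1=O)Nc1ccc(Br)cc1`: 66500 nM
- compound 3, `Cc1cccc(NC(=O)CSC(=S)N[C@H]2CCOC2=O)c1C`: only a limit, > 128000 nM

On these data alone, compound 3 stands apart from the other two in that its result is not a number but the limit of this assay (the limit of > 128000 nM in this assay, at which 1 of the 3 values shown sits); where it sits above that limit is unknown. Compound 4, `Cc1cccc(NC(=O)CSC(=S)N[C@H]2CCOC2=O)c1`, keeps the shared core and differs from compound 3 only by hydrogen in place of methyl on an aromatic carbon of the six-membered aromatic ring of carbon only.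

Among the compounds with values here, only one measured step exists, a 2.3-fold higher number from compound 1 to compound 2 (0.37 log units; beyond the scatter), and it exchanges the whole aryl group on the amide-type nitrogen rather than removing a single methyl; it was modest. Within the data shown here, no measured step removes a methyl from the ring, so nothing directly calibrates the change from compound 3 to compound 4. Given that the one known step was modest, a step of comparable size is expected here, an at least 1.1-fold lower number from compound 3 to compound 4 (0.06 log units; that floor lies within the scatter), with the direction uncertain because compound 3 gives only the limit > 128000 nM. Compound 4 is therefore estimated to lie near the limit in this assay, at about 110000 nM, with a range from 35000 nM to 300000 nM, and a real chance that it too returns only a limit.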

Compound 4, half-maximal inhibitory concentration: 63200 nM
Beside the measured number, compound 4's estimate is 1.7-fold (0.24 log units) above it, within the range that was stated.
By their numbers in this assay, from the lowest: compound 1; then compounds 4 and 2 (each within the scatter of the next). At a limit, above all of these: compound 3.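

In this assay, hydrogen in place of methyl on an aromatic carbon, ortho to a large group and ortho to a methyl group, gives an at least 2.0-fold lower number from compound 3 to compound 4 (0.30 log units; that floor lies within the scatter), and the result for compound 3 is only a limit: the limit of > 128000 nM in this assay, at which 1 of the 4 values shown sits.

The 3-methylphenyl group on the amide-type nitrogen cannot be told apart from the 4-bromophenyl group, a 1.1-fold lower number from compound 2 to compound 4 (0.02 log units; within the scatter), whereas against the 2-fluorophenyl group it gives a 2.2-fold higher number from compound 1 to compound 4 (0.34 log units; beyond the scatter). Compound 4 keeps one methyl on the ring and still returns a number, so a ring methyl alone does not bring a compound of this series to the limit, and compound 3 remains the only one shown that ends there.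

On these data alone, how far beyond its limit compound 3 lies stays unknown, so the true size of this step stays open, and it may be much larger than its floor. Also open, as far as these compounds go, is whether an unsubstituted phenyl group, or an amine or a carboxylic acid on the ring in place of the remaining methyl, would move the number beyond the scatter from compound 4.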